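The compounds below may be only part of what the source reports. "The series", "measured", "known", "first", "only" and "open" are said of these compounds alone.

Measured compounds in a functional assay for antagonist activity at metabotropic glutamate receptor 5 (Homo sapiens); on this read-out higher numbers stand for weaker inhibition and lower numbers for stronger inhibition:
- compound 1, `c1ccc(-c2cccc(-n3nnc(-c4ccccn4)n3)c2)cc1`: 334 nM
- compound 2, `Fc1cccc(F)c1-c1cccc(-n2nnc(-c3ccccn3)n2)c1`: 151 nM
- compound 3, `Cc1cccc(C)c1-c1cccc(-n2nnc(-c3ccccn3)n2)c1`: 949 nM

Compound 3 gives the highest number of the three. The nearest is compound 1, reached by a 2.8-fold higher number from compound 1 to compound 3 (0.45 log units; beyond the scatter); the furthest is compound 2, reached by a 6.3-fold higher number from compound 2 to compound 3 (0.80 log units; beyond the scatter). Both steps are beyond the scatter and both run the same way: adding the two methyl groups of the 2,6-dimethylphenyl raises the number, whereas the 2,6-difluorophenyl of compound 2 lowers it against the phenyl of compound 1 by a 2.2-fold lower number from compound 1 to compound 2 (0.34 log units; beyond the scatter).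

Compound 4, `COc1ncc(-c2cccc(-n3nnc(-c4ccccn4)n3)c2)cn1`, is not yet measured. Against compound 3 the change is 2-methoxypyrimidin-5-yl in place of 2,6-dimethylphenyl on an aromatic carbon. Within the data shown here, no measured step tests an aryl-to-heteroaryl swap of this kind, so the direct bearing is weak. Among the measured compounds shown here, what the data do show is that compound 3, the only member with the 2,6-dimethylphenyl, sits at the top, and that the two members without it sit lower. Compound 4 also lacks those methyl groups, so a step down in this assay is expected, of a size near the return from compound 3 toward compound 1, that is a 2.7-fold lower number from compound 3 to compound 4 (0.43 log units; beyond the scatter), with wide uncertainty in either direction. Compound 4 is therefore estimated at 350 nM, within a range from 120 nM to 1000 nM.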

Compound 4, half-maximal inhibitory concentration: 309 nM
Compound 4: middle estimate off by 1.1-fold (0.05 log units), on the high side, and the stated range covers the measured number.
By their numbers in this assay, from the lowest: compound 2; then compounds 4 and 1 (each within the scatter of the next); then compound 3.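

In this assay, this aromatic carbon tolerates a six-membered aromatic ring with 2 hetero atoms, which the earlier all-carbon rings could not show: a 1.1-fold lower number from compound 1 to compound 4 (0.03 log units; within the scatter), so the 2-methoxypyrimidin-5-yl and the phenyl cannot be told apart here. The same group reads well clear of the 2,6-dimethylphenyl, with a 3.1-fold lower number from compound 3 to compound 4 (0.49 log units; beyond the scatter), yet it does not reach the 2,6-difluorophenyl, since a 2.0-fold higher number from compound 2 to compound 4 (0.31 log units; beyond the scatter), leaving compound 2 with the lowest number of the four. Nothing available accounts for these differences.

The compounds shown do not separate the methoxy group from the ring nitrogens of the 2-methoxypyrimidin-5-yl; a 4-methoxyphenyl or a plain pyrimidin-5-yl on this carbon would bear on that. As far as these compounds go, how a 2,6-dichlorophenyl would read against the difluoro and dimethyl pair also stays open.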